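The source may report more compounds than this note shows. Statements on the series, on what has been measured and on what is new or still open speak of the compounds shown alone.

Series notes. Compound 3 `COc1ccc(NC(=O)[C@H]2CCCN2C(=O)C2(c3cccc(Cl)c3)CCCC2)cc1` gives the highest number of the three measured compounds in an assay on isolated protein for inhibition of histone acetyltransferase p300 (Homo sapiens), with a stated time of 60 min (a higher number here means a weaker inhibitor, a lower number a stronger inhibitor), at 100 nM. Its nearest neighbour is compound 1 `COc1ccc(NC(=O)[C@H]2CCCN2C(=O)C2(c3cccc(Cl)c3)CCCC2)nc1`, which gives 2 nM in this assay; the step is a 50-fold higher number from compound 1 to compound 3 (1.70 log units; beyond the scatter). Furthest is compound 2 `O=C(Nc1ccc2[nH]ncc2n1)[C@H]1CCCN1C(=O)C1(c2cccc(Cl)c2)CCCC1`, which gives 0.159 nM; the step is a 630-fold higher number from compound 2 to compound 3 (2.80 log units; beyond the scatter). Between the two stronger compounds the step is a 13-fold lower number from compound 1 to compound 2 (1.10 log units; beyond the scatter). All three steps change only the aryl group on the amide-type nitrogen, and all are beyond the scatter, so this position is where the series moves.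

Compound 4 `CNC(=O)c1cccc(NC(=O)[C@H]2CCCN2C(=O)C2(c3cccc(Cl)c3)CCCC2)c1` is the next variation at the same place: 3-(methylcarbamoyl)phenyl in place of 4-methoxyphenyl on an amide-type nitrogen. Among the compounds with values here, no measured step covers a carbamoyl group there, so the bearing of the existing steps is indirect: they show that exchanging the aryl on this nitrogen has shifted the number by large amounts in both directions, and that the all-carbon ring of compound 3 sits at the weak end. A step of moderate size toward a lower number is expected in this assay, with wide uncertainty, as a 2.5-fold lower number from compound 3 to compound 4 (0.40 log units; beyond the scatter). Compound 4 is therefore estimated at 40 nM, in the range 5 nM to 300 nM.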

Compound 4, half-maximal inhibitory concentration: 1260 nM
Compound 4: middle estimate off by 32-fold (1.50 log units), on the low side, and the stated range ends below it.
By their numbers in this assay, from the lowest: compound 2; then compound 1; then compound 3; then compound 4.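

Series notes, continued. In this assay the all-carbon ring of compound 3 no longer marks the weak end of the series: a 13-fold higher number from compound 3 to compound 4 (1.10 log units; beyond the scatter) shows that one all-carbon aryl group on the amide-type nitrogen can differ sharply from another, so the presence of such a ring does not set the number by itself. Compound 4 now has the highest number of the four, and the measured span at this position widens (a 7900-fold higher number from compound 2 to compound 4 (3.90 log units; beyond the scatter)), with the gap to the methoxypyridine also large (a 630-fold higher number from compound 1 to compound 4 (2.80 log units; beyond the scatter)). No supporting data bear on the origin of this step.

Left open is how much of the step belongs to the methylcarbamoyl group itself and how much to where it stands on the ring; 3-(methylcarbamoyl)phenyl and 4-methoxyphenyl differ in both the substituent and its place. Also open, on these data alone, is what a plain phenyl, a carboxylic acid or a dimethylamino group would give on the same nitrogen with the core of compound 3 unchanged.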